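Side-chain oxygen step from compound 3 to compound 4

A few compounds are considered here, and "the series" means these few. Any claim that something is new, unique, unknown or untested is made for them only; others in the source may bear on it.

Values in a functional assay on A549 cells (Homo sapiens) for inhibition, read by sulforhodamine B assay, with a stated time of 72 h (a higher number here means a weaker inhibitor, a lower number a stronger inhibitor), for the measured compounds
compound 1 `COc1cc2c(Nc3ccc(F)c(Cl)c3)ncnc2cc1OCCOCCn1ccnc1[N+](=O)[O-]` gives 12900 nM
compound 2 `C#Cc1cccc(Nc2ncnc3cc(OCCOCCn4ccnc4[N+](=O)[O-])c(OC)cc23)c1` gives 9770 nM
compound 3 `COc1cc2c(Nc3cccc(Br)c3)ncnc2cc1OCCCCn1ccnc1[N+](=O)[O-]` gives 3090 nM

Compound 3 has the lowest of the three numbers, and its gaps to the other two lie beyond the scatter. The next compound is compound 4 `COc1cc2c(Nc3cccc(Br)c3)ncnc2cc1OCCOCCn1ccnc1[N+](=O)[O-]` and the change is 2-(2-nitro-1H-imidazol-1-yl)ethoxy in place of 2-(2-nitro-1H-imidazol-1-yl)ethyl on a saturated chain carbon, two bonds along the chain from an oxygen on an aromatic ring which gives compound 4 the chain carried by compound 1 and compound 2. Among the compounds with values here, no measured step isolates this chain change. Within the data shown here, the only measured step is a 1.3-fold lower number from compound 1 to compound 2 (0.12 log units; within the scatter) with 3-ethynylphenyl in place of 3-chloro-4-fluorophenyl on a nitrogen on an aromatic ring. Compound 3 differs from compound 1 and compound 2 at that nitrogen as well as in the chain, so its gap to them cannot be split between the two changes. Since that one step stays within the scatter, compound 4 is expected to lie close to compound 2 at 9770 nM and not close to compound 3. The expected size and direction in this assay is a 2.9-fold higher number from compound 3 to compound 4 (0.46 log units; beyond the scatter) as an estimate with wide uncertainty.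
For compound 4 the estimated value is 9000 nM with an expected range from 4000 nM to 18000 nM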

Compound 4, half-maximal inhibitory concentration: 13000 nM
Beside the measured number, compound 4's estimate is 1.4-fold (0.16 log units) below it; low and high end bracket the measured number.
By their numbers in this assay, from the lowest: compound 3; then compounds 2, 1 and 4 (each within the scatter of the next).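

In this assay, within the data shown here, with the 3-bromophenyl group held fixed, the chain change alone gives a 4.2-fold higher number from compound 3 to compound 4 (0.62 log units; beyond the scatter) and so is the first isolated change to lie beyond the scatter. With the 2-(2-nitro-1H-imidazol-1-yl)ethoxy chain held fixed, the group on the nitrogen shows no readable effect among compounds 1, 2 and 4: a 1.3-fold higher number from compound 2 to compound 4 (0.12 log units; within the scatter) and a 1.0-fold higher number from compound 1 to compound 4 (0.00 log units; within the scatter) both stay within the scatter, as does a 1.3-fold lower number from compound 1 to compound 2 (0.12 log units; within the scatter). Nothing available bears on why the chain change shifts the number.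

As far as these compounds go, the 2-(2-nitro-1H-imidazol-1-yl)ethyl chain appears here only with 3-bromophenyl, so whether the chain step holds with 3-chloro-4-fluorophenyl or 3-ethynylphenyl remains open. From the compounds shown here alone, how a longer chain, or an amine in place of the chain oxygen, would read in this assay also remains open.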